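Difluoromethoxy for Fluoro on a Benzimidazole Antagonist Series

This account rests on a few compounds, and the source may have more. Where it says the series, first, only, none or still open, it means among the compounds named here.

Three compounds share a common core and were compared in a functional assay on HEK293 cells for antagonist activity at transient receptor potential M8 protein (Canis lupus familiaris), read by FLIPR and calcium flux; a higher number here means a weaker inhibitor, a lower number a stronger inhibitor. Compound 1 `FC(F)(F)c1ccccc1-c1ccc2[nH]c(C3=NCC4(CCCCC4)O3)nc2c1` gives 61 nM, and compound 2 `FC(F)(F)c1ccccc1-c1ccc2[nH]c(C3=NC4(CCCCC4)CO3)nc2c1` gives 6 nM. Compound 3 `Fc1ccccc1-c1ccc2[nH]c(C3=NOC4(CCCCC4)C3)nc2c1` gives 2.9 nM, the lowest of the three numbers; its gap to compound 2 and its gap to compound 1 both lie beyond the usual scatter, so compound 3 is the strongest inhibitor shown here. Compound 4 `FC(F)Oc1ccccc1-c1ccc2[nH]c(C3=NOC4(CCCCC4)C3)nc2c1` differs from compound 3 by one change: difluoromethoxy in place of fluoro on an aromatic carbon. Among the compounds with values here, no measured pair shows this change, so its effect is unknown. The step from compound 3 to compound 4 is expected to be small, most likely a modest weakening, as a 1.7-fold higher number from compound 3 to compound 4 (0.24 log units; within the scatter). Compound 4 is estimated at 5 nM in this assay , within 1.5 nM to 20 nM.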

Compound 4, half-maximal inhibitory concentration: 2.5 nM
The estimate for compound 4 lay 2.0-fold (0.30 log units) above the measured number, and the stated range covers the measured number.
By their numbers in this assay, from the lowest: compounds 4 and 3 (each within the scatter of the next); then compound 2; then compound 1.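

In this assay, difluoromethoxy in place of fluoro on the aromatic carbon ortho to a large group gives a 1.2-fold lower number from compound 3 to compound 4 (0.06 log units; within the scatter), a step within the scatter. Within the data shown here, this is the first measured reading of this change, and it shows that this position accepts a group with more heavy atoms and a hydrogen-bond acceptor while the number stays within the scatter. No measurement shown explains why the two compounds read alike. As far as these compounds go, what an amine or a carboxylic acid would do on this aromatic carbon stays open. So does whether difluoromethoxy would read the same on the core of compound 2.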